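Exchanging a fluorobenzyl for a phenylethyl group

A few compounds are considered here, and "the series" means these few. Any claim that something is new, unique, unknown or untested is made for them only; others in the source may bear on it.

Compounds measured so far:
compound 1, `Cc1ccc(-c2nc(N)c3cc(C(C)c4ccccc4)sc3n2)o1`: 439 nM
compound 2, `Cc1csc(-c2nc(N)c3cc(Cc4ccccc4Cl)sc3n2)n1`: 49.6 nM
compound 3, `Cc1csc(-c2nc(N)c3cc(Cc4ccccc4F)sc3n2)n1`: 28.6 nM

In a functional assay on CHO-K1 cells for antagonist activity at adenosine receptor A1 (Homo sapiens), read by a beta-galactosidase reporter and cAMP accumulation, with stated times of 15 min and 6 h (a lower number here means a stronger inhibitor, a higher number a weaker inhibitor), compound 3 gives the lowest number of the three, 28.6 nM, yet compound 2 with 49.6 nM stands within the scatter of it, so the two cannot be ranked. Compound 1 with 439 nM is clearly apart from both. Going by the values given here, the only single-change step in this set, a 1.7-fold lower number from compound 2 to compound 3 (0.24 log units; within the scatter), concerns a halogen swap and does not speak to the change now in view.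

Compound 4, `Cc1csc(-c2nc(N)c3cc(C(C)c4ccccc4)sc3n2)n1`, arises from compound 3 by 1-phenylethyl in place of 2-fluorobenzyl on an aromatic carbon. Among the compounds with values here, no measured pair isolates this change. Compound 1 carries the same 1-phenylethyl group but differs from compound 3 in a second place as well, so its higher number cannot be attributed to either change alone. The author therefore expects a step of a 5.2-fold higher number from compound 3 to compound 4 (0.72 log units; beyond the scatter) toward a higher number, leaning on the direction suggested by compound 1, with wide uncertainty. The estimate for compound 4 in this assay is 150 nM, with a range from 50 nM to 450 nM.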

Compound 4, inhibition constant: 1420 nM
Estimate against measurement, compound 4: 9.5-fold (0.98 log units) below, and the stated range ends below it.
By their numbers in this assay, from the lowest: compounds 3 and 2 (each within the scatter of the next); then compound 1; then compound 4.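

With the 4-methyl-1,3-thiazol-2-yl group held constant, this assay shows a 50-fold higher number from compound 3 to compound 4 (1.70 log units; beyond the scatter) when 1-phenylethyl replaces 2-fluorobenzyl, and a 29-fold higher number from compound 2 to compound 4 (1.46 log units; beyond the scatter) when it replaces 2-chlorobenzyl, so this aromatic carbon next to the ring sulfur tolerates the exchange poorly, whichever of the two halogenated benzyl groups is given up. With 1-phenylethyl held constant, the change in the other place can now be read on its own: a 3.2-fold higher number from compound 1 to compound 4 (0.51 log units; beyond the scatter) comes with 4-methyl-1,3-thiazol-2-yl in place of 5-methylfuran-2-yl, which means that this exchange also moves the number, though only modestly. Nothing available on these compounds beyond the numbers themselves accounts for the size of either change.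

The compounds shown leave open whether the step at this position comes from the methyl on the carbon that links the phenyl ring or from the loss of the halogen, a question that a plain benzyl group would separate. Also open, on these data alone, is how a 2-methoxybenzyl group or a 2-phenylethyl chain on this aromatic carbon would read.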